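This account rests on a few compounds, and the source may have more. Where it says the series, first, only, none or still open, it means among the compounds named here.

Going by the values given here, compound 2 `CCc1nc2ccccc2n1CCCCOc1ccc(Cl)cc1F` stands lowest of the two numbers in an ADME assay on Vero cells (Chlorocebus sabaeus) for cytotoxicity, read by luminescence, with a stated time of 2 days (a lower number here means that less compound is tolerated, a higher number that more compound is tolerated), at 5.7 uM, while compound 1 `CCc1nc2ccccc2n1CCCCOc1cccc(C)c1` gives 19 uM; the only measured step is a 3.3-fold lower number from compound 1 to compound 2 (0.52 log units; beyond the scatter). Compound 3 `CCc1nc2ccccc2n1CCCCOC` differs from compound 2 by methyl in place of 4-chloro-2-fluorophenyl on an oxygen on a saturated carbon. That step swapped one aromatic ring for another, whereas here the ring is lost altogether, so it bears on the change only loosely. Compound 3 is expected to move back toward compound 1 by a modest step, a 2.6-fold higher number from compound 2 to compound 3 (0.42 log units; beyond the scatter). Compound 3 is therefore estimated at 15 uM in this assay, between 6 uM and 40 uM.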

Compound 3, half-maximal toxic concentration: > 50 uM
Compound 3: only a limit was reported (the forecaster's own chance of this, stated with the estimate: 15%); at least 3.3-fold (0.52 log units) between middle value and limit.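

Compound 3 is reported in this assay only as a limit: the limit of > 50 uM in this assay, at which 1 of the 3 values shown sits. Putting methyl on this oxygen gives an at least 8.7-fold higher number from compound 2 to compound 3 (0.94 log units; beyond the scatter), and measured against the other aromatic ring it gives an at least 2.6-fold higher number from compound 1 to compound 3 (0.42 log units; beyond the scatter). Going by these compounds alone, the earlier pair showed only that one aromatic ring differs from another here, whereas these steps show that losing the ring raises the number past both compounds that carry one. As far as these compounds go, how far compound 3 lies beyond its limit stays open. So does whether an unsubstituted phenyl, a longer chain or an amine on this oxygen would read like methyl or like the aromatic rings.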